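This account rests on a few compounds, and the source may have more. Where it says the series, first, only, none or still open, it means among the compounds named here.

In an ADME assay on WI-38 cells (Homo sapiens) for cytotoxicity, read by MTT assay, with a stated time of 72 h; a higher number here means a weaker inhibitor, a lower number a stronger inhibitor:
Compound 1 `CN(C)CCn1cnnc1-c1cc(Oc2ccc(NC(=O)Nc3cccc(C(F)(F)F)c3)cc2F)ccn1` gives 11200 nM.
Compound 2 `CN(C)CCn1cnnc1-c1cc(Oc2ccc(NC(=O)Nc3ccccc3C(F)(F)F)cc2F)ccn1` gives > 50000 nM, which is a limit of the assay and not a number.

Compound 2 thus stands at the limit of > 50000 nM in this assay, at which 1 of the 2 values shown sits, so no number of its own is known; what is known is the step of an at least 4.4-fold higher number from compound 1 to compound 2 (0.64 log units; beyond the scatter), which placed compound 2 beyond the reach of the assay. Compound 3 `CN(C)CCn1cnnc1-c1cc(Oc2ccc(NC(=O)Nc3ccc(F)c(Cl)c3)cc2F)ccn1` differs from compound 2 in one place: 3-chloro-4-fluorophenyl in place of 2-(trifluoromethyl)phenyl on an amide-type nitrogen. Within the data shown here, no measured step covers this pair exactly. Among the measured compounds shown here, the only step that bears on it is the one from compound 1 to compound 2, in which 2-(trifluoromethyl)phenyl replaced 3-(trifluoromethyl)phenyl and the number rose by an at least 4.4-fold higher number from compound 1 to compound 2 (0.64 log units; beyond the scatter). Compound 3 carries its halogens as 3-chloro-4-fluorophenyl, a pattern nearer to that of compound 1 than to that of compound 2, so the number is expected to come back down from the limit of compound 2, by about an at least 3.3-fold lower number from compound 2 to compound 3 (0.52 log units; beyond the scatter), though a second limit cannot be ruled out. For compound 3 the estimate in this assay is 15000 nM, with a likely range from 5000 nM to 50000 nM.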

Compound 3, half-maximal inhibitory concentration: 7580 nM
Compound 3: middle estimate off by 2.0-fold (0.30 log units), on the high side, within the range that was stated.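

In this assay the replacement of 2-(trifluoromethyl)phenyl by 3-chloro-4-fluorophenyl on the amide-type nitrogen gives an at least 6.5-fold lower number from compound 2 to compound 3 (0.81 log units; beyond the scatter) and brings the read-out back to a measured number, so the earlier finding at this position is not a general result of changing the aryl group there. The second comparison gives a 1.5-fold lower number from compound 1 to compound 3 (0.17 log units; within the scatter) and therefore does not separate 3-chloro-4-fluorophenyl from 3-(trifluoromethyl)phenyl, which means that two differently substituted phenyl groups now read alike in this assay while 2-(trifluoromethyl)phenyl stands apart from both. The value of compound 2 remains a limit and not a number, so it alone lacks a measured value: the limit of > 50000 nM in this assay, at which 1 of the 3 values shown sits.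

The compounds shown cannot tell whether the separate standing of compound 2 goes with the trifluoromethyl group itself or with where it sits on the phenyl ring, a question that a 2-chlorophenyl or a 4-(trifluoromethyl)phenyl group at the same nitrogen would address. They also leave open how an unsubstituted phenyl group, or a pyridine ring in place of the phenyl, would read in this assay.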